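Exchanging the group on the amine nitrogen of compound 3

The compounds below may be only part of what the source reports. "The series", "measured", "known", "first", "only" and "open" are said of these compounds alone.

For the measured compounds named here, in a functional assay on Pfeiffer cells (Homo sapiens) for cytotoxicity, read by scintillation counting and thymidine incorporation, with a stated time of 4 days (a lower number here means a stronger inhibitor, a higher number a weaker inhibitor), compound 3 `COc1c([C@H](C)Nc2ncnc3[nH]cnc23)cc(Cl)c(C)c1-c1cncc(S(C)(=O)=O)c1` gives 40 nM, the lowest of the three numbers so far. That number lies within the scatter of compound 2 `COc1c([C@H](C)Nc2ncnc(N)c2C#N)cc(Cl)c(C)c1-c1ccc(C(=O)N(C)C)cn1`, which gives 61 nM. Compound 1 `COc1c([C@H](C)Nc2ncnc3[nH]cnc23)cc(Cl)c(C)c1-c1cnn(C)c1` gives 950 nM and stands well beyond the scatter from compound 3.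

Compound 4 `COc1c([C@H](C)Nc2ncnc(N)c2C#N)cc(Cl)c(C)c1-c1cncc(S(C)(=O)=O)c1` keeps the 5-(methylsulfonyl)pyridin-3-yl group of compound 3 and alters only the group on the amine nitrogen, where 6-amino-5-cyanopyrimidin-4-yl enters: a group of 9 heavy atoms (5 carbon, 4 nitrogen; one six-membered aromatic ring with 2 hetero atoms) in place of a group of 9 heavy atoms (5 carbon, 4 nitrogen; one five-membered aromatic ring with 2 hetero atoms, one six-membered aromatic ring with 2 hetero atoms), on an amine nitrogen.

Going by the values given here, the one measured step, a 24-fold lower number from compound 1 to compound 3 (1.38 log units; beyond the scatter), is large, but it concerns the exchange of 1-methyl-1H-pyrazol-4-yl for 5-(methylsulfonyl)pyridin-3-yl on an aromatic carbon, so it does not speak directly to this change. Among the compounds with values here, no measured pair isolates the exchange on the amine nitrogen. The closest evidence is compound 2, which already carries 6-amino-5-cyanopyrimidin-4-yl and gives 61 nM, although it also has a different group on the aromatic carbon. From the compounds shown here alone, on that loose comparison, no step beyond the scatter is expected in this assay, and the direction remains open. The expected change is a 1.1-fold lower number from compound 3 to compound 4 (0.06 log units; within the scatter). For compound 4 the estimated value is 35 nM, with an expected range of 10 nM to 120 nM.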

Compound 4, half-maximal inhibitory concentration: 17 nM
Estimate against measurement, compound 4: 2.1-fold (0.31 log units) above, within the range that was stated.
By their numbers in this assay, from the lowest: compound 4; then compounds 3 and 2 (each within the scatter of the next); then compound 1.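

The exchange on the amine nitrogen now has a direct reading in this assay: 6-amino-5-cyanopyrimidin-4-yl gives a 2.4-fold lower number from compound 3 to compound 4 (0.37 log units; beyond the scatter) and thus a modest gain, even though the two groups have the same atoms, joined differently. With 6-amino-5-cyanopyrimidin-4-yl held fixed, 5-(methylsulfonyl)pyridin-3-yl in place of 5-(dimethylcarbamoyl)pyridin-2-yl gives a 3.6-fold lower number from compound 2 to compound 4 (0.55 log units; beyond the scatter) and separates two compounds whose earlier counterparts could not be linked by a single change, so both positions now show a step beyond the scatter in this pair of exchanges. Nothing on hand explains either step.

From the compounds shown here alone, the exchange on the amine nitrogen has been read with 5-(methylsulfonyl)pyridin-3-yl alone on the aromatic carbon, so whether it carries over to another group there, such as 1-methyl-1H-pyrazol-4-yl, remains open. Also open, going by these compounds, is how much of the step depends on the nitrile of 6-amino-5-cyanopyrimidin-4-yl, which a carboxamide or a methyl group in its place would address.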